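Working notes: tert-butoxycarbonyl to methyl on the ring amine

The source may hold more compounds than are shown below. What is called first, only, known or untested is meant among the compounds shown, and "the series" means these compounds.

Measured so far in a functional assay on PC-3 cells (Homo sapiens) for cytotoxicity, read by MTT assay, with a stated time of 48 h; a lower number here means a stronger inhibitor, a higher number a weaker inhibitor:
compound 1, `CC1=NN(C(=O)CN2CCN(C(=O)OC(C)(C)C)CC2)C(c2ccccc2O)C1`, gives 3440 nM
compound 2, `CC1=NN(C(=O)CN2CCN(C)CC2)C(c2ccccc2O)C1`, gives 11800 nM
compound 3, `CC(C)(C)OC(=O)N1CCN(CC(=O)N2N=C(c3cc4ccccc4oc3=O)CC2c2ccccc2)CC1`, gives 36400 nM

Compound 1 and compound 2 share a core and differ in one place: methyl in place of tert-butoxycarbonyl on an amine nitrogen in a ring. That change gave a 3.4-fold higher number from compound 1 to compound 2 (0.54 log units; beyond the scatter). Compound 3 sits on a different core; the difference between the two cores is not broken down here. Among the three values, compound 3 has the highest number in this assay, and its two neighbours both lie beyond the usual scatter from it.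

Compound 4, `CN1CCN(CC(=O)N2N=C(c3cc4ccccc4oc3=O)CC2c2ccccc2)CC1`, is not yet measured. It carries the same change as the earlier pair: methyl in place of tert-butoxycarbonyl on an amine nitrogen in a ring. The place is the same in both pairs, so this is the same change, made a second time on the core of compound 3.

Among the measured compounds shown here, with only one earlier instance of the change to go on, a step of like direction and size is expected for compound 4: because a 3.4-fold higher number from compound 1 to compound 2 (0.54 log units; beyond the scatter) went towards a higher number, compound 4 is expected to move by about a 3.0-fold higher number from compound 3 to compound 4 (0.48 log units; beyond the scatter). The estimate for compound 4 in this assay is 110000 nM, within 40000 nM to 300000 nM, with some chance that only a limit is reported.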

Compound 4, half-maximal inhibitory concentration: 25800 nM
For compound 4 the middle estimate is 4.3-fold (0.63 log units) above the measured one, outside the stated range (below it).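

In this assay, methyl in place of tert-butoxycarbonyl on the ring amine nitrogen gives a 1.4-fold lower number from compound 3 to compound 4 (0.15 log units; within the scatter), so on the core of compound 3 this change leaves no readable difference. The change does not carry a fixed step from one core to the other: the same change on two cores in this assay, a 3.4-fold higher number (0.54 log units; beyond the scatter) from compound 1 to compound 2 and a 1.4-fold lower number (0.15 log units; within the scatter) from compound 3 to compound 4, 4.8-fold (0.68 log units) apart, beyond the scatter of two such steps. Among the compounds shown here, with one pair on each core, this shows only that the step seen on the core of compound 1 cannot be assumed on the core of compound 3; it does not show what in the cores separates the two steps, or whether either step is typical of its core.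

On this nitrogen the compounds shown carry only tert-butoxycarbonyl and methyl, which leaves open whether an acetyl group, a benzyl group or the free secondary amine would follow the pattern of the core of compound 1 or that of compound 3. No pair shown changes the core in one place, so which part of the core matters also stays open.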